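Working notes on a benzylsulfanyl series: three measured, one estimated

A few compounds are considered here, and "the series" means these few. Any claim that something is new, unique, unknown or untested is made for them only; others in the source may bear on it.

Measured compounds, read-out in a functional assay on the whole organism (artery, strain albino) with Rattus norvegicus as the target, with a stated time of 240 min, at a dose of 10 mg/kg by the oral route; on this read-out lower numbers stand for less inhibition and higher numbers for more inhibition at the one dose given (going by the name of the read-out):
compound 1 `COc1ccc(C2N=C(SCc3ccccc3)NC(C)=C2C(=O)Nc2ccc(F)cc2)cc1OC`: 11.8%
compound 2 `COc1ccc(C2N=C(SCc3ccccc3Cl)NC(C)=C2C(=O)Nc2ccc(F)cc2)cc1OC`: 30.3%
compound 3 `COc1ccc(C2N=C(SCc3cccc(Cl)c3)NC(C)=C2C(=O)Nc2ccc(F)cc2)cc1OC`: 14.9%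

Compound 3 stands second highest of the three numbers: the nearer gap is a number 3.1 percentage points higher from compound 1 to compound 3 (within the scatter), while the further gap is a number 15.4 percentage points lower from compound 2 to compound 3 (beyond the scatter). Compound 4 `COc1ccc(C2N=C(SCc3ccc(F)cc3)NC(C)=C2C(=O)Nc2ccc(F)cc2)cc1OC` is not yet measured; it differs from compound 3 by 4-fluorophenyl in place of 3-chlorophenyl on a saturated chain carbon bound to a sulfur. Among the measured compounds shown here, no measured step introduces a fluorine on this ring. For the measured compounds named here, the steps that bear on it are the two chloro steps, a number 18.5 percentage points higher from compound 1 to compound 2 (beyond the scatter) and a number 3.1 percentage points higher from compound 1 to compound 3 (within the scatter); one of them left the number where it was, the other moved it. Since the step to compound 3 itself was the quiet one, a step within the scatter is expected for compound 4, a number 1.1 percentage points higher from compound 3 to compound 4 (within the scatter). Compound 4 is accordingly estimated at 16%, in the range 6% to 28%.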

Compound 4, a percentage reported as inhibition, in the whole organism at one dose (the size of the read-out at that dose, not a potency): 28.7%
The estimate for compound 4 lay 12.7 percentage points below the measured number, outside the stated range (above it).
By their numbers in this assay, from the lowest: compounds 1 and 3 (each within the scatter of the next); then compounds 4 and 2 (each within the scatter of the next).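

On the saturated chain carbon bound to a sulfur, a fluoro substituent also moves the number in this assay (a number 16.9 percentage points higher from compound 1 to compound 4 (beyond the scatter)), and 4-fluorophenyl separates from 3-chlorophenyl (a number 13.8 percentage points higher from compound 3 to compound 4 (beyond the scatter)). 4-Fluorophenyl stays level with 2-chlorophenyl (a number 1.6 percentage points lower from compound 2 to compound 4 (within the scatter)), so among the substituted compounds, compound 3 alone goes against a rise over compound 1.

Still open, from the compounds shown here alone, is whether a methoxy, an amine or a carboxylic acid on this ring would raise the number as these halogens do. Nothing available accounts for these steps.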